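A few compounds are considered here, and "the series" means these few. Any claim that something is new, unique, unknown or untested is made for them only; others in the source may bear on it.

Of the compounds shown here, three that share one core have been tested in an assay on HEK293 cells for displacement of a labelled ligand from growth hormone secretagogue receptor type 1 (Homo sapiens), with a stated time of 60 min; a lower number here means a stronger inhibitor, a higher number a weaker inhibitor. Compound 1 `CN1CCN(CCCS(=O)(=O)c2ccc3nc(NC(=O)NC(=O)c4cc(-n5cccn5)ccc4Cl)sc3c2)CC1` gives 0.67 nM. Compound 2 `CN1CCC(S(=O)(=O)c2ccc3nc(NC(=O)NC(=O)c4cc(N5CCCC5)ccc4Cl)sc3c2)CC1` gives 0.92 nM. Compound 3 `Cc1cc(C)n(-c2ccc(Cl)c(C(=O)NC(=O)Nc3nc4ccc(S(=O)(=O)CCCN5CCN(C)CC5)cc4s3)c2)n1` gives 1.3 nM, the highest of the three numbers, though its gaps to compound 2 and to compound 1 both fall within the scatter. Among the measured compounds shown here, the only step that links two measured compounds differing in one place, a 1.9-fold higher number from compound 1 to compound 3 (0.29 log units; within the scatter), also falls within the scatter.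

Compound 4 `CN1CCN(CCCS(=O)(=O)c2ccc3nc(NC(=O)NC(=O)c4cc(N5CCCC5)ccc4Cl)sc3c2)CC1` has not yet been measured. It differs from compound 3 in one place: pyrrolidin-1-yl in place of 3,5-dimethyl-1H-pyrazol-1-yl on an aromatic carbon. For the measured compounds named here, no measured step covers exactly this exchange. Going by the values given here, still, compound 2 carries the same pyrrolidin-1-yl group while differing elsewhere, and its value in this assay sits close to that of compound 3; and the one measured step, which changed only the group on that aromatic carbon, stayed within the scatter. On that basis compound 4 is expected to show a 1.6-fold lower number from compound 3 to compound 4 (0.21 log units; within the scatter), a step not beyond the scatter. Compound 4 is therefore estimated at 0.8 nM, with a range from 0.3 nM to 2 nM.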

Compound 4, half-maximal inhibitory concentration: 0.29 nM
Beside the measured number, compound 4's estimate is 2.8-fold (0.44 log units) above it, and the stated range ends above it.
By their numbers in this assay, from the lowest: compound 4; then compounds 1, 2 and 3 (each within the scatter of the next).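

Among the compounds shown here, on the aromatic carbon para to a chloro group, the earlier compounds showed only an exchange between 1H-pyrazol-1-yl and 3,5-dimethyl-1H-pyrazol-1-yl that stayed within the scatter, whereas the non-aromatic pyrrolidin-1-yl stands apart from both aromatic groups in this assay (a 4.5-fold lower number from compound 3 to compound 4 (0.65 log units; beyond the scatter); a 2.3-fold lower number from compound 1 to compound 4 (0.36 log units; beyond the scatter)). This position therefore responds to the group placed on it, and in both pairs the lower number goes with pyrrolidin-1-yl. The group on the sulfonyl sulfur matters too, as 3-(4-methylpiperazin-1-yl)propyl in place of 1-methylpiperidin-4-yl gives a clear step (a 3.2-fold lower number from compound 2 to compound 4 (0.50 log units; beyond the scatter)).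

Going by these compounds, whether a six-membered piperidin-1-yl or an open-chain dimethylamino group on that aromatic carbon would follow pyrrolidin-1-yl remains open. Nothing available explains why these exchanges lower the number.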